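This account rests on a few compounds, and the source may have more. Where it says the series, first, only, none or still open, it means among the compounds named here.

In an ADME assay on L6 cells (Rattus norvegicus) for cytotoxicity, read by resazurin assay, with a stated time of 72 h (a higher number here means a weaker inhibitor, a lower number a stronger inhibitor), three compounds on a shared core have been measured: compound 1 (`N#Cc1ccc(C(=O)NC(=O)c2ccccc2O)cc1`), compound 2 (`COC(=O)c1ccc(C(=O)NC(=O)c2ccccc2O)cc1`) and compound 3 (`CCCCOc1ccc(C(=O)NC(=O)c2ccccc2O)cc1`). Compound 3 gives 13 ug/mL and holds the lowest of the three numbers, while compound 2 gives 42 ug/mL and compound 1 gives 55 ug/mL within the scatter of each other. Compound 4 (`Nc1ccc(C(=O)NC(=O)c2ccccc2O)cc1`) differs from compound 3 in one place (amino in place of butoxy on an aromatic carbon). For the measured compounds named here, no measured step involves amino, so the evidence is indirect. Butoxy in place of cyano gave a 4.2-fold lower number from compound 1 to compound 3 (0.63 log units; beyond the scatter) and butoxy in place of methoxycarbonyl gave a 3.2-fold lower number from compound 2 to compound 3 (0.51 log units; beyond the scatter) as modest steps, whereas exchanging cyano for methoxycarbonyl gave only a 1.3-fold lower number from compound 1 to compound 2 (0.12 log units; within the scatter) inside the scatter. Losing butoxy is therefore expected to reverse a step of similar, modest size. The expected step in this assay is a 3.5-fold higher number from compound 3 to compound 4 (0.54 log units; beyond the scatter) towards a higher number. Compound 4 is estimated at 45 ug/mL with an expected range of 18 ug/mL to 95 ug/mL around that middle.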

Compound 4, half-maximal inhibitory concentration: 39 ug/mL
For compound 4 the middle estimate is 1.2-fold (0.06 log units) above the measured one; the measured number falls inside the stated range.
By their numbers in this assay, from the lowest: compound 3; then compounds 4, 2 and 1 (each within the scatter of the next).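

In this assay, amino in place of butoxy gave a 3.0-fold higher number from compound 3 to compound 4 (0.48 log units; beyond the scatter) and so removed the lower number seen with butoxy, on an aromatic carbon para to a large group. Amino in place of methoxycarbonyl gave a 1.1-fold lower number from compound 2 to compound 4 (0.03 log units; within the scatter) while amino in place of cyano gave a 1.4-fold lower number from compound 1 to compound 4 (0.15 log units; within the scatter), so amino, with its hydrogen-bond donor, joins those two groups and butoxy alone stands apart among the four groups at this position. Nothing measured here accounts for that separation.

The compounds shown leave open whether the lower number of compound 3 needs the full butoxy chain, or whether methoxy or a longer alkoxy chain would give it too. They also leave open whether a butyl chain joined directly to the aromatic carbon, without the ether oxygen, or a butylamino group would stand with compound 3 or with compound 4.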